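The compounds below may be only part of what the source reports. "The series", "measured", "known", "first", "only" and "open" are said of these compounds alone.

Compound 1 `CC(C)CCOc1ccccc1C1CC(=O)c2ccccc2O1` gives 42600 nM in a functional assay on J774.A1 cells (Mus musculus) for inhibition, read by Griess assay, with stated times of 1 h and 24 h (on this read-out lower numbers stand for stronger inhibition and higher numbers for weaker inhibition), and compound 2 `CCCOc1ccccc1C1CC(=O)c2ccccc2O1` gives 44600 nM there, while compound 3 `O=C1CC(c2ccccc2OCc2ccccc2)Oc2ccccc21` gives 23200 nM on the same read-out. Compound 3 cannot be ranked against the other two, since both steps to it lie within the scatter, namely a 1.8-fold lower number from compound 1 to compound 3 (0.26 log units; within the scatter) and a 1.9-fold lower number from compound 2 to compound 3 (0.28 log units; within the scatter) as measured.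

Compound 4 `COc1ccccc1C1CC(=O)c2ccccc2O1` keeps the shared core but has not yet been measured. It differs from compound 3 by hydrogen in place of phenyl on a saturated chain carbon bound to an oxygen on an aromatic ring, so benzyloxy becomes methoxy.

The two steps to compound 3 bear most directly on this change. They involve phenyl at the same carbon. The third, a 1.0-fold higher number from compound 1 to compound 2 (0.02 log units; within the scatter) in size, shows that the two chains of compound 1 and compound 2 are not told apart by this measurement. None of the three steps exceeds the scatter, so no step beyond the scatter is expected in this assay here, and any drift would be toward a higher number, nearer compound 1 and compound 2. The expected size is a 1.7-fold higher number from compound 3 to compound 4 (0.24 log units; within the scatter) and it stays within the scatter. The estimate for compound 4 is 40000 nM with an expected range from 19000 nM to 80000 nM for most repeat measurements.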

Compound 4, half-maximal inhibitory concentration: 44500 nM
Estimate against measurement, compound 4: 1.1-fold (0.05 log units) below, and the stated range covers the measured number.
By their numbers in this assay, from the lowest: compounds 3, 1, 4 and 2 (each within the scatter of the next).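

In this assay, hydrogen in place of phenyl on this saturated chain carbon, which turns benzyloxy into methoxy, gives a 1.9-fold higher number from compound 3 to compound 4 (0.28 log units; within the scatter), so removing an entire aromatic ring from the group does not produce a change that can be read. The smaller chains add the same message: hydrogen in place of ethyl gives a 1.0-fold lower number from compound 2 to compound 4 (0.00 log units; within the scatter), and hydrogen in place of isobutyl gives a 1.0-fold higher number from compound 1 to compound 4 (0.02 log units; within the scatter). With methoxy now included, every pair among the four compounds lies within the scatter, so hydrogen, ethyl, isobutyl and phenyl at this carbon cannot be told apart on this read-out, and methoxy already does as well as any of the larger groups shown.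

No supporting data explain why these groups read alike. It remains open whether an amine, a carboxylic acid or a chain longer than those shown at this carbon would give a step beyond the scatter, or whether this position simply has little influence on the read-out.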